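A few compounds are considered here, and "the series" means these few. Any claim that something is new, unique, unknown or untested is made for them only; others in the source may bear on it.

Measured compounds:
- compound 1, `C=CC(=O)Nc1cccc(NC(=O)CSc2nc(Nc3ccccc3Br)c3ccccc3n2)c1`, gives 12800 nM in a functional assay on MGC-803 cells (Homo sapiens) for inhibition, read by MTT assay, with a stated time of 72 h; a lower number here means a stronger inhibitor, a higher number a weaker inhibitor
- compound 2, `C=CC(=O)Nc1cccc(NC(=O)CSc2nc(Nc3cccc(F)c3)c3ccccc3n2)c1`, gives 6250 nM in this assay
- compound 3, `C=CC(=O)Nc1cccc(NC(=O)CSc2nc(Nc3ccc(Cl)cc3)c3ccccc3n2)c1`, gives 14300 nM in this assay

Compound 3 has the highest of the three numbers, but its gap to compound 1 is within the scatter: a 1.1-fold higher number from compound 1 to compound 3 (0.05 log units; within the scatter). Only compound 2 stands apart from it, by a 2.3-fold higher number from compound 2 to compound 3 (0.36 log units; beyond the scatter). Compound 4, `C=CC(=O)Nc1cccc(NC(=O)CSc2nc(Nc3ccc(Cl)cc3Cl)c3ccccc3n2)c1`, has not yet been measured. It differs from compound 3 by chloro in place of hydrogen on an aromatic carbon, so a second chloro group is added to the same ring that already carries one.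

Among the measured compounds shown here, none of the measured steps adds a group to an existing ring; all three swap one whole aryl group for another. Those swaps gave steps of a 2.0-fold lower number from compound 1 to compound 2 (0.31 log units; beyond the scatter), a 1.1-fold higher number from compound 1 to compound 3 (0.05 log units; within the scatter) and a 2.3-fold higher number from compound 2 to compound 3 (0.36 log units; beyond the scatter), so changes on this ring have so far moved the number little. Adding one chloro group is expected to stay within that span, with no step beyond the scatter in this assay in either direction: a 1.0-fold lower number from compound 3 to compound 4 (0.01 log units; within the scatter) is the expected step. Compound 4 is therefore estimated at 14000 nM, with a range from 6000 nM to 35000 nM.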

Compound 4, half-maximal inhibitory concentration: 12100 nM
Compound 4: middle estimate off by 1.2-fold (0.06 log units), on the high side; the measured number falls inside the stated range.
By their numbers in this assay, from the lowest: compounds 2, 4, 1 and 3 (each within the scatter of the next, the first and the last beyond it).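

Among the compounds shown here, compound 4 is the first case here of a group being added to a ring rather than one aryl group replacing another. A chloro group on the aromatic carbon ortho to a large group and meta to a chloro group gives a 1.2-fold lower number from compound 3 to compound 4 (0.07 log units; within the scatter) in this assay, so the added group produces no readable difference from the single-chloro ring. The 2,4-dichlorophenyl group also stays within the scatter of both other aryl groups, with a 1.9-fold higher number from compound 2 to compound 4 (0.29 log units; within the scatter) and a 1.1-fold lower number from compound 1 to compound 4 (0.02 log units; within the scatter), so compound 4 cannot be grouped with either end of the series, even though compound 2 and compound 3 lie beyond the scatter of each other. No other measurement bears on this result, so what lies behind these numbers remains unexplained.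

On these data alone, every ring at this position carries only halogens, so its response to a methoxy group, an amine or a carboxylic acid remains open. It is also unknown whether a second chloro group would give the same result on the ring of compound 2, which has the lowest number of the series, as it does on the ring of compound 3.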